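Swapping an aryl amide for a cyclopropylaminoacetyl group

The source may hold more compounds than are shown below. What is called first, only, known or untested is meant among the compounds shown, and "the series" means these compounds.

Compound 1 `CC1=NN(C(=O)CN2CCN(C)CC2)C(c2ccccc2O)C1` gives 11800 nM in a functional assay on PC-3 cells (Homo sapiens) for cytotoxicity, read by MTT assay, with a stated time of 48 h; on this read-out higher numbers stand for weaker inhibition and lower numbers for stronger inhibition.
Compound 2 `Cc1ccc(C(=O)N2N=C(c3cc4ccccc4oc3=O)CC2c2ccccc2)cc1` gives 13200 nM in this assay.

Within the data shown here, only two compounds have been measured, and they share no single-point structural step. Compound 2 and compound 1 give numbers that lie within the scatter of each other, so neither stands apart; both are weak inhibitors in this assay.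

Compound 3 `O=C(CNC1CC1)N1N=C(c2cc3ccccc3oc2=O)CC1c1ccccc1` is the unmeasured one. It keeps the core of compound 2 and changes only the group on the carbonyl carbon: (cyclopropylamino)methyl in place of 4-methylphenyl on a carbonyl carbon. Among the measured compounds shown here, no measured step of this kind is available, so there is no direct guide to its size or direction.

With nothing to point either way, the expected step from compound 2 to compound 3 in this assay is a 1.1-fold lower number from compound 2 to compound 3 (0.04 log units; within the scatter), that is, none beyond the scatter. Compound 3 is therefore estimated at 12000 nM, with a range from 4000 nM to 40000 nM.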

Compound 3, half-maximal inhibitory concentration: 28500 nM
For compound 3 the middle estimate is 2.4-fold (0.38 log units) below the measured one, and the stated range covers the measured number.
By their numbers in this assay, from the lowest: compounds 1 and 2 (each within the scatter of the next); then compound 3.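

In this assay, the group on this carbonyl carbon turns out to matter: a 2.2-fold higher number from compound 2 to compound 3 (0.33 log units; beyond the scatter), a modest move towards weaker inhibition. The exchange changes several things at once, as a ring of carbon-only aromatic character leaves and a three-membered ring and a nitrogen enter, so this one step cannot show which of these differences counts. No measurement at hand accounts for the shift.

Going by these compounds, what remains open is which part of (cyclopropylamino)methyl goes with the higher number. On these data alone, a cyclopropylmethyl group, which has no nitrogen, or a benzyl group, which keeps an aromatic ring, on the same carbonyl carbon would help to separate the two, and whether the step holds on another core also remains unknown.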